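The compounds below may be only part of what the source reports. "The series", "measured", "known", "first", "only" and "open" are said of these compounds alone.

Within the data shown here, in an assay on isolated protein for inhibition of Arachidonate 12-lipoxygenase (Sus scrofa) (a higher number here means a weaker inhibitor, a lower number a stronger inhibitor), compound 3 `CCCCCCCCC#CCOCc1ccc(CCC(=O)O)cc1` gives 100 nM, the only number among the three values shown. Compound 1 `CCCCCCCCC#CCSCc1cccc(CCC(=O)O)c1` reaches only the limit of > 10000 nM in this assay. Compound 2 `CCCCCCCCCCC#CCOCc1ccc(CCCC(=O)O)cc1` likewise reaches only the limit of > 10000 nM. Two of the three values shown therefore sit at the limit of > 10000 nM in this assay, at which 2 of the 3 values shown sit. Compound 4 `CCCCCCCCCCCCC#CCOCc1ccc(CCC(=O)O)cc1` has not yet been measured in this assay; it differs from compound 3 by butyl in place of hydrogen on a saturated chain carbon, eight bonds along the chain from a triple-bonded carbon. Among the measured compounds shown here, no step between two measured compounds is available, so the expectation rests on the values alone. Compound 2 carries a longer saturated chain than compound 3 and reaches only a limit. On that ground a weakening beyond the scatter is expected for compound 4, as the step of a 10-fold higher number from compound 3 to compound 4 (1.00 log units; beyond the scatter). Compound 4 is expected to give 1000 nM, between 200 nM and 10000 nM.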

Compound 4, half-maximal inhibitory concentration: 320 nM
Compound 4: the middle estimate sits 3.1-fold (0.49 log units) above what was measured, within the range that was stated.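

In this assay, among these compounds, butyl in place of hydrogen on a saturated chain carbon, eight bonds along the chain from a triple-bonded carbon, gives a 3.2-fold higher number from compound 3 to compound 4 (0.51 log units; beyond the scatter), the first step that can be read at this position. The change therefore weakens inhibition only modestly, and compound 4 keeps a measured number and does not join the values held at the assay's limit: the limit of > 10000 nM in this assay, at which 2 of the 4 values shown sit. The compounds shown leave open how a shorter group such as methyl or propyl would read at this position, and whether an amine or a carboxylic acid would be accepted there.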